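A few compounds are considered here, and "the series" means these few. Any claim that something is new, unique, unknown or untested is made for them only; others in the source may bear on it.

Compound 1 `Nc1ncnc2c1nc(N)n2[C@@H]1O[C@H](COP(=O)(O)OP(=O)(O)OC[C@H]2OC(O)[C@H](O)[C@@H]2O)[C@@H](O)[C@H]1O` is the reference point of this small series. In an assay on HEK293 cells for antagonist activity at transient receptor potential cation channel subfamily M member 2 (Homo sapiens), read by patch clamp (a higher number here means a weaker inhibitor, a lower number a stronger inhibitor), compound 1 gives "not active" (no number reported), so no single number stands for it and it cannot be placed on the scale; it marks the inactive end of what has been measured. Among the compounds with values here, compound 2 `Nc1ncnc2c1nc(-c1ccccc1)n2[C@@H]1O[C@H](COP(=O)(O)OP(=O)(O)OC2CCCC2)[C@@H](O)[C@H]1O` is the only member with a numerical read-out: in this assay compound 2 gives 15000 nM, a weak inhibition, and no single-point step connects it to compound 1, so the two only show that a measured weak value and an inactive result sit side by side in the set.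

Compound 3 `O=c1[nH]cnc2c1ccn2[C@@H]1O[C@H](COP(=O)(O)OP(=O)(O)OC[C@H]2OC(O)[C@H](O)[C@@H]2O)[C@@H](O)[C@H]1O` has not been measured. It differs from compound 1 by a group of 10 heavy atoms (6 carbon, 3 nitrogen, 1 oxygen; one five-membered aromatic ring with 1 hetero atom, one six-membered aromatic ring with 2 hetero atoms) in place of a group of 11 heavy atoms (5 carbon, 6 nitrogen; one five-membered aromatic ring with 2 hetero atoms, one six-membered aromatic ring with 2 hetero atoms), on a saturated ring carbon. Within the data shown here, no measured pair isolates this kind of exchange of the heteroaromatic group on the saturated ring carbon, so the direction of the step in this assay cannot be read from data; the expectation is that compound 3 stays in the weak range, if it gives a number at all. Compound 3 is estimated at 40000 nM, with a range from 8000 nM to 200000 nM.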

Compound 3, half-maximal inhibitory concentration: "not active" (no number reported)
For compound 3 the study gives words and no number; there is nothing to compare the estimate with.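

Like compound 1, compound 3 gives "not active" (no number reported) in this assay, so no step can be read between the two. The compounds shown leave open whether this exchange of the group on the saturated ring carbon changes inhibition at all. No measurement shown offers an explanation for the result.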